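The compounds below may be only part of what the source reports. "The series", "measured", "known", "first", "only" and "open" are said of these compounds alone.

Measured in a functional assay on A549 cells (Homo sapiens) for antiproliferative activity, read by MTT assay, with a stated time of 72 h; a lower number here means a stronger inhibitor, a higher number a weaker inhibitor:
- Compound 1 `C=CC(=O)Nc1cc(Nc2nccc(NC(=O)c3cccc(OC)c3)n2)c(OC)cc1N1CCN(C)CC1`: 6450 nM
- Compound 2 `C=CC(=O)Nc1cc(Nc2nccc(NC(=O)c3ccc(C(F)(F)F)cc3)n2)c(OC)cc1N1CCN(C)CC1`: 7890 nM
- Compound 3 `C=CC(=O)Nc1cc(Nc2nccc(NC(=O)c3cccc(OC)c3)n2)c(OC)cc1N(C)CCN(C)C`: 3000 nM

Of these three, compound 3 has the lowest number, at 3000 nM, and its distance from each of the other two exceeds the usual scatter. The modest gain that sets it apart from its closest comparison is a 2.2-fold lower number from compound 1 to compound 3 (0.33 log units; beyond the scatter).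

Compound 4 `C=CC(=O)Nc1cc(Nc2nccc(NC(=O)c3ccc(C(F)(F)F)cc3)n2)c(OC)cc1N(C)CCN(C)C` has not yet been measured. It keeps the (2-(dimethylamino)ethyl)(methyl)amino group of compound 3 and changes the other end of the molecule: 4-(trifluoromethyl)phenyl in place of 3-methoxyphenyl on a carbonyl carbon. In words, 4-(trifluoromethyl)phenyl stands in place of 3-methoxyphenyl on a carbonyl carbon.

The same exchange has been measured once, on the 4-methylpiperazin-1-yl series, as a 1.2-fold higher number from compound 1 to compound 2 (0.09 log units; within the scatter). That step lies within the scatter. The other measured step, a 2.2-fold lower number from compound 1 to compound 3 (0.33 log units; beyond the scatter), concerns a different site and serves only to place the starting point. With a single precedent, the data cannot show whether the exchange behaves alike in both series. Resting on a 1.2-fold higher number from compound 1 to compound 2 (0.09 log units; within the scatter), no change beyond the scatter is expected in this assay, with at most a slight rise in the number. The expected step is a 1.2-fold higher number from compound 3 to compound 4 (0.08 log units; within the scatter). For compound 4 the estimated value is 3600 nM, with an expected range of 1800 nM to 7000 nM.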

Compound 4, half-maximal inhibitory concentration: 9880 nM
Compound 4: the middle estimate sits 2.7-fold (0.44 log units) below what was measured; the measured number lies above the stated range.
By their numbers in this assay, from the lowest: compound 3; then compounds 1, 2 and 4 (each within the scatter of the next).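

In this assay, the exchange of 3-methoxyphenyl for 4-(trifluoromethyl)phenyl on a carbonyl carbon no longer leaves the number in place once the (2-(dimethylamino)ethyl)(methyl)amino group is present, giving a 3.3-fold higher number from compound 3 to compound 4 (0.52 log units; beyond the scatter). The two sites therefore do not act independently, since the size of the step depends on the group at the other end of the molecule: the same change on two cores in this assay, a 1.2-fold higher number (0.09 log units; within the scatter) from compound 1 to compound 2 and a 3.3-fold higher number (0.52 log units; beyond the scatter) from compound 3 to compound 4, 2.7-fold (0.43 log units) apart, beyond the scatter of two such steps. Read from the other site, the exchange of 4-methylpiperazin-1-yl for (2-(dimethylamino)ethyl)(methyl)amino, which gave a gain with 3-methoxyphenyl, gives none with 4-(trifluoromethyl)phenyl, only a 1.3-fold higher number from compound 2 to compound 4 (0.10 log units; within the scatter), and the two readings of that exchange differ as well: the same change on two cores in this assay, a 2.2-fold lower number (0.33 log units; beyond the scatter) from compound 1 to compound 3 and a 1.3-fold higher number (0.10 log units; within the scatter) from compound 2 to compound 4, 2.7-fold (0.43 log units) apart, beyond the scatter of two such steps.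

As far as these compounds go, these four compounds form a single set of two groups at each of two sites, so it remains open whether the same dependence holds for any other group on the carbonyl carbon or at the amine site. A 3-(trifluoromethyl)phenyl or 4-methoxyphenyl group would separate the place of the substituent from its kind, and a morpholine in place of the amine groups would test how far the dependence extends.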